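Boc Removal on a Thiazolopyridine Core in K562 Cells

A few compounds are considered here, and "the series" means these few. Any claim that something is new, unique, unknown or untested is made for them only; others in the source may bear on it.

The account concerns three measured compounds and one unmeasured one, all carrying the same amide to a chloro-trifluoromethylphenyl group and the same triazole-linked pyrrolidine, and differing in the aromatic core and in the substitution of the ring nitrogen. In a functional assay on K562 cells (Homo sapiens) for inhibition, read by MTT assay, with a stated time of 48 h (a lower number here means a stronger inhibitor, a higher number a weaker inhibitor), compound 1 `CC(C)(C)OC(=O)N1C[C@@H](n2cc(-c3ccc4c(N)n[nH]c4c3)nn2)C[C@H]1C(=O)Nc1ccc(Cl)c(C(F)(F)F)c1` gives 10500 nM. Compound 2 `Nc1n[nH]c2cc(-c3cn([C@@H]4CN[C@H](C(=O)Nc5ccc(Cl)c(C(F)(F)F)c5)C4)nn3)ccc12` differs from it by hydrogen in place of tert-butoxycarbonyl on an amine nitrogen in a ring and in this assay gives 8320 nM; the step of a 1.3-fold lower number from compound 1 to compound 2 (0.10 log units; within the scatter). Compound 3 `CC(C)(C)OC(=O)N1C[C@@H](n2cc(-c3ccc4nc(N)sc4n3)nn2)C[C@H]1C(=O)Nc1ccc(Cl)c(C(F)(F)F)c1` carries a different core, the difference being (a group of 10 heavy atoms (6 carbon, 3 nitrogen, 1 sulfur; one five-membered aromatic ring with 2 hetero atoms, one six-membered aromatic ring with 1 hetero atom) in place of a group of 10 heavy atoms (7 carbon, 3 nitrogen; one five-membered aromatic ring with 2 hetero atoms, one six-membered aromatic ring of carbon only), on an aromatic carbon), and in this assay gives 10900 nM, the step being a 1.0-fold higher number from compound 1 to compound 3 (0.02 log units; within the scatter). For the measured compounds named here, compound 4 `Nc1nc2ccc(-c3cn([C@@H]4CN[C@H](C(=O)Nc5ccc(Cl)c(C(F)(F)F)c5)C4)nn3)nc2s1` is related to compound 3 by hydrogen in place of tert-butoxycarbonyl on an amine nitrogen in a ring, which is the same change as the one from compound 1 to compound 2, the place of the change being described in the same words for both pairs.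

Because the step of a 1.3-fold lower number from compound 1 to compound 2 (0.10 log units; within the scatter) stayed within the scatter, the same change on the core of compound 3 is expected to move the number little, and the estimate for compound 4 in this assay rests on that single earlier step. On that basis the step of a 1.3-fold lower number from compound 3 to compound 4 (0.10 log units; within the scatter) is expected, and compound 4 is estimated at 8700 nM, with a range from 4000 nM to 19000 nM to reflect the scatter of measurements of this kind.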

Compound 4, half-maximal inhibitory concentration: 26200 nM
For compound 4 the middle estimate is 3.0-fold (0.48 log units) below the measured one, and the stated range ends below it.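

In this assay, hydrogen in place of tert-butoxycarbonyl on an amine nitrogen in a ring gives a 2.4-fold higher number from compound 3 to compound 4 (0.38 log units; beyond the scatter), so this change does not act alike on the two cores: the same change on two cores in this assay, a 1.3-fold lower number (0.10 log units; within the scatter) from compound 1 to compound 2 and a 2.4-fold higher number (0.38 log units; beyond the scatter) from compound 3 to compound 4, 3.0-fold (0.48 log units) apart, beyond the scatter of two such steps. Read from the other side, the change of core gives a 3.1-fold higher number from compound 2 to compound 4 (0.50 log units; beyond the scatter) when the ring nitrogen bears hydrogen, whereas the two cores stay within the scatter of each other when it bears tert-butoxycarbonyl, so the two changes do not combine independently in these four compounds: the same change on two cores in this assay, a 1.0-fold higher number (0.02 log units; within the scatter) from compound 1 to compound 3 and a 3.1-fold higher number (0.50 log units; beyond the scatter) from compound 2 to compound 4, 3.0-fold (0.48 log units) apart, beyond the scatter of two such steps. For the compounds shown here, this shows that the step seen on the core of compound 1 could not be carried over to the core of compound 3 in this assay, but it does not show why, and with only two cores it does not show how the change would behave on any other core.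

The compounds shown leave open whether a different group on that ring nitrogen, such as an acetyl or a methyl group, would follow tert-butoxycarbonyl or hydrogen on either core. They also leave open whether the same difference between the cores would hold with another amide partner, such as a phenyl group carrying neither the chlorine nor the trifluoromethyl.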